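Trading the anilino urea for a dimethylamino urea

The source may report more compounds than this note shows. Statements on the series, on what has been measured and on what is new or still open speak of the compounds shown alone.

Of the compounds shown here, three sharing one core have been measured in an assay on isolated protein for binding affinity to secreted frizzled-related protein 1 (Homo sapiens), read by fluorescence; on this read-out higher numbers stand for weaker inhibition and lower numbers for stronger inhibition. Compound 1 `CN(C)c1ccc(C(=O)N2CCC[C@H]2C(=O)N2CCC(NS(=O)(=O)c3cc(S(=O)(=O)c4ccccc4)ccc3C(F)(F)F)CC2)cc1` gives 110 nM, compound 2 `O=C([C@@H]1CCCN1C(=O)c1ccncc1)N1CCC(NS(=O)(=O)c2cc(S(=O)(=O)c3ccccc3)ccc2C(F)(F)F)CC1` gives 70 nM, and compound 3 `O=C([C@@H]1CCCN1C(=O)Nc1ccccc1)N1CCC(NS(=O)(=O)c2cc(S(=O)(=O)c3ccccc3)ccc2C(F)(F)F)CC1` gives 20 nM. Compound 3 thus stands at the lowest number of the three: the step of a 5.5-fold lower number from compound 1 to compound 3 (0.74 log units; beyond the scatter) and the step of a 3.5-fold lower number from compound 2 to compound 3 (0.54 log units; beyond the scatter) both favour it beyond the scatter, while the step of a 1.6-fold lower number from compound 1 to compound 2 (0.20 log units; within the scatter) stays within it. Compound 4 `CN(C)C(=O)N1CCC[C@H]1C(=O)N1CCC(NS(=O)(=O)c2cc(S(=O)(=O)c3ccccc3)ccc2C(F)(F)F)CC1` differs from compound 3 by dimethylamino in place of anilino on a carbonyl carbon. Among the measured compounds shown here, none of the measured steps removes the aromatic ring from the carbonyl carbon; the two steps that bear on this position show only that the anilino group gives lower numbers than either aryl group. With the ring and its hydrogen-bond donor gone, the number for compound 4 is expected to rise, the step of a 5.0-fold higher number from compound 3 to compound 4 (0.70 log units; beyond the scatter) being the estimate, though the absence of a direct precedent leaves it uncertain. In this assay compound 4 is estimated at 100 nM, with a range from 30 nM to 400 nM.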

Compound 4, half-maximal inhibitory concentration: 30 nM
Beside the measured number, compound 4's estimate is 3.3-fold (0.52 log units) above it; the range from low to high includes it.
By their numbers in this assay, from the lowest: compounds 3 and 4 (each within the scatter of the next); then compounds 2 and 1 (each within the scatter of the next).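

In this assay the step of a 1.5-fold higher number from compound 3 to compound 4 (0.18 log units; within the scatter) shows that the anilino group can give way to dimethylamino on this carbonyl carbon without a change beyond the scatter, even though the aromatic ring and the hydrogen-bond donor are gone. Dimethylamino also stands apart from the two aryl groups, with a 2.3-fold lower number from compound 2 to compound 4 (0.37 log units; beyond the scatter) and a 3.7-fold lower number from compound 1 to compound 4 (0.56 log units; beyond the scatter) in this assay, so among these four compounds the two lower numbers go with a nitrogen on the carbonyl carbon, aromatic ring or not. No evidence is at hand on what lies behind this.

From the compounds shown here alone, whether that nitrogen itself counts remains open, and a carbon-linked group such as isopropyl would bear on it. Also open, going by these compounds, is how a methylamino group or a morpholine ring would compare at this position.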